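A few compounds are considered here, and "the series" means these few. Any claim that something is new, unique, unknown or untested is made for them only; others in the source may bear on it.

Among the compounds with values here, the three compounds measured so far share the core of compound 1 `COc1ccc(CN(c2cc(OC)c(OC)c(OC)c2)S(=O)(=O)c2ccc(C(C)(C)C)cc2)cc1`, which in a functional assay on PC-3 cells (Homo sapiens) for inhibition, read by MTT assay, with a stated time of 48 h (on this read-out lower numbers stand for stronger inhibition and higher numbers for weaker inhibition), gives 28600 nM. Compound 2 `COc1cc(N(Cc2ccc(F)cc2)S(=O)(=O)c2ccc(C)cc2)cc(OC)c1OC` gives 20700 nM in this assay, and compound 3 `COc1cc(N(Cc2ccc(Br)cc2)S(=O)(=O)c2ccc(C)cc2)cc(OC)c1OC` gives 4680 nM in this assay. Compound 3 thus stands at the lowest of the three numbers, with compound 2 nearest and compound 1 furthest away. Within the data shown here, the only step between compounds that differ in a single place is a 4.4-fold lower number from compound 2 to compound 3 (0.65 log units; beyond the scatter). Compound 1 differs from compound 3 in more than one place, so its value and that of compound 3 can only be set side by side.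

Compound 4 `COc1cc(N(Cc2csc3ccc(Cl)cc23)S(=O)(=O)c2ccc(C)cc2)cc(OC)c1OC` has not yet been measured. It differs from compound 3 by 5-chloro-1-benzothiophen-3-yl in place of 4-bromophenyl on a saturated chain carbon bound to a sulfonamide nitrogen. Among the measured compounds shown here, no measured pair shows this change. For the measured compounds named here, the one step that touches the same part of the molecule is a 4.4-fold lower number from compound 2 to compound 3 (0.65 log units; beyond the scatter), in which exchanging one halogen for another on an aromatic carbon moved the number beyond the scatter, so this part of the molecule is not indifferent to change. That step gives no direction for the 5-chloro-1-benzothiophen-3-yl group, so in this assay the step is expected to be a 1.0-fold lower number from compound 3 to compound 4 (0.02 log units; within the scatter), most likely within or just beyond the scatter. Compound 4 is therefore estimated at 4500 nM, with a range from 1200 nM to 18000 nM.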

Compound 4, half-maximal inhibitory concentration: 15300 nM
Compound 4: middle estimate off by 3.4-fold (0.53 log units), on the low side, within the range that was stated.
By their numbers in this assay, from the lowest: compound 3; then compounds 4, 2 and 1 (each within the scatter of the next).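

At this position, on a saturated chain carbon bound to a sulfonamide nitrogen, the exchange of 4-bromophenyl for 5-chloro-1-benzothiophen-3-yl registers in this assay as a step beyond the scatter (a 3.3-fold higher number from compound 3 to compound 4 (0.51 log units; beyond the scatter)), so the position responds to a change of the whole aromatic group and not only to an exchange of one halogen for another. Set against the 4-fluorophenyl group, the same two-ring group gives a step within the scatter (a 1.4-fold lower number from compound 2 to compound 4 (0.13 log units; within the scatter)), so compound 2 and compound 4 cannot be told apart, and among these three groups only the 4-bromophenyl group of compound 3 stands apart, with steps beyond the scatter to both of the others. No measurement at hand offers a reason for either step.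

The compounds shown do not separate the chlorine of the 5-chloro-1-benzothiophen-3-yl group from its second ring, so it remains open which of the two goes with the step from the 4-bromophenyl group. Also open, going by these compounds, is how an amine or a carboxylic acid in place of the bromine of compound 3 (4680 nM) would read at this position.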